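From a thiophene to a difluorophenyl amide: solubility

The source may report more compounds than this note shows. Statements on the series, on what has been measured and on what is new or still open speak of the compounds shown alone.

Of the compounds shown here, three sharing one core have been measured in a physicochemical assay for solubility, at pH 7; on this read-out lower numbers stand for lower solubility and higher numbers for higher solubility. Compound 1 `CN1CCC(C(=O)N2Cc3c(NC(=O)c4ccsc4)n[nH]c3C2(C)C)CC1` carries a thiophen-3-yl group on the amide carbonyl, and its result in this assay is a limit of the assay rather than a number, > 225000 nM. Compound 3 `CCN1CCC(C(=O)N2Cc3c(NC(=O)c4ccc(F)cc4)n[nH]c3C2(C)C)CC1` likewise gives only a limit in this assay, > 225000 nM. Compound 2 `CN1CCC(C(=O)N2Cc3c(NC(=O)c4cccs4)n[nH]c3C2(C)C)CC1` is the only one of the three with a number, giving 155000 nM in this assay. It stands as the single measured point. Compounds 1 and 3 both sit at the limit of > 225000 nM in this assay, at which 2 of the 3 values shown sit. For the measured compounds named here, the one step between compounds that differ in a single place is an at least 1.4-fold lower number from compound 1 to compound 2 (0.16 log units; that floor lies within the scatter).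

Compound 4 `CN1CCC(C(=O)N2Cc3c(NC(=O)c4ccc(F)c(F)c4)n[nH]c3C2(C)C)CC1` has not been measured. It differs from compound 2 by 3,4-difluorophenyl in place of thiophen-2-yl on a carbonyl carbon. Going by the values given here, no measured step swaps a thiophene for a fluorinated phenyl ring. Among the compounds with values here, the only guide is that the isomer swap in an at least 1.4-fold lower number from compound 1 to compound 2 (0.16 log units; that floor lies within the scatter) stayed within the scatter, and that compound 3, which also carries a fluorophenyl group but differs from compound 4 elsewhere as well, reaches the limit in this assay. The expected step is a 1.0-fold lower number from compound 2 to compound 4 (0.01 log units; within the scatter), with wide uncertainty. Compound 4 is estimated at 150000 nM in this assay, between 60000 nM and 225000 nM.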

Compound 4, solubility: > 225000 nM
Compound 4: a limit, no number; the forecaster's own chance of this, stated with the estimate: 35%; middle value at least 1.5-fold (0.17 log units) away from the limit.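

At this position, on a carbonyl carbon whose other neighbour is an amide-type nitrogen, the change from a five-membered aromatic ring holding sulfur to a six-membered carbon-only ring bearing two fluorines brings no drop in the reading of this assay, and the step is an at least 1.4-fold higher number from compound 2 to compound 4 (0.16 log units; that floor lies within the scatter). For the compounds shown here, this is the first measured change of ring type at this position, as the earlier step only swapped one thiophene isomer for the other, and the larger difluorinated ring still leaves compound 4 at a limit of the assay rather than a number. The step between compound 1 and compound 4 cannot be read, and the series now rests mostly on limits rather than numbers: the limit of > 225000 nM in this assay, at which 3 of the 4 values shown sit.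

As far as these compounds go, how far compound 1, compound 3 and compound 4 actually lie beyond that limit stays unknown, so this assay cannot rank them against one another. Also open, from the compounds shown here alone, is whether a much larger or differently built group on the same carbonyl carbon, such as a naphthyl ring or a long alkyl chain, would bring the reading down to a clear number.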